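Series notes: isopropyl to tert-butyl, outlook for compound 4

The source may report more compounds than this note shows. Statements on the series, on what has been measured and on what is new or still open speak of the compounds shown alone.

Measured so far in an assay on isolated protein for inhibition of Polyunsaturated fatty acid 5-lipoxygenase (Homo sapiens), read by fluorescence and spectrophotometry, with a stated time of 10 min; on this read-out lower numbers stand for stronger inhibition and higher numbers for weaker inhibition:
- compound 1 `O=[N+]([O-])c1ccc2c(c1)S(=O)(=O)N=C2Nc1ccccc1` gives 8600 nM
- compound 2 `COc1ccc(NC2=NS(=O)(=O)c3cc([N+](=O)[O-])ccc32)cc1OC` gives 23500 nM
- compound 3 `CC(C)c1cccc(NC2=NS(=O)(=O)c3cc([N+](=O)[O-])ccc32)c1` gives 250 nM

Compound 3 stands lowest of the three numbers. Among the compounds with values here, its nearest neighbour is compound 1, separated by the step of a 34-fold lower number from compound 1 to compound 3 (1.54 log units; beyond the scatter); compound 2, with no single-place step to compound 3, shows the highest number of the three, and the gap between compound 3 and compound 2 is beyond the scatter.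

Compound 4 `CC(C)(C)c1cccc(NC2=NS(=O)(=O)c3cc([N+](=O)[O-])ccc32)c1` differs from compound 3 by methyl in place of hydrogen on a saturated chain carbon bound to an aromatic carbon and two saturated chain carbons. Within the data shown here, the only measured step that bears on this change is a 34-fold lower number from compound 1 to compound 3 (1.54 log units; beyond the scatter), which is large and runs toward lower numbers; it shows that building out this position from hydrogen to isopropyl lowers the number in this assay. Among the measured compounds shown here, no measured pair shows what one further methyl on the already substituted chain carbon does. The expectation is therefore a step of modest size at most, in the direction of a lower number or none beyond the scatter, since the large gain from compound 1 to compound 3 is not a reason to expect a second gain of the same size.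

Compound 4 is expected to give about 200 nM in this assay, within a range from 70 nM to 600 nM. The expected step from compound 3 to compound 4 is a 1.3-fold lower number from compound 3 to compound 4 (0.10 log units; within the scatter), estimated to lie within the scatter.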

Compound 4, half-maximal inhibitory concentration: 60 nM
Beside the measured number, compound 4's estimate is 3.3-fold (0.52 log units) above it; measured number below the stated range.
By their numbers in this assay, from the lowest: compound 4; then compound 3; then compound 1; then compound 2.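

In this assay the change from isopropyl to tert-butyl continues in the same direction (a 4.2-fold lower number from compound 3 to compound 4 (0.62 log units; beyond the scatter)) and lies beyond the scatter, so the fall in the number from hydrogen to isopropyl (a 34-fold lower number from compound 1 to compound 3 (1.54 log units; beyond the scatter)) does not end at isopropyl. A single further methyl, 1 heavy atom, on the saturated chain carbon bound to an aromatic carbon and two saturated chain carbons still moves the number, though by a smaller step than the one from hydrogen to isopropyl. Taken whole, tert-butyl in place of hydrogen on an aromatic carbon gives the largest step in the series so far (a 140-fold lower number from compound 1 to compound 4 (2.16 log units; beyond the scatter)), and compound 4 now holds the lowest of the four numbers.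

How a longer chain, a phenyl ring or an amine in place of tert-butyl would compare remains open, so the compounds shown do not mark where the fall in the number stops. Also open, as far as these compounds go, is whether these steps would hold with a nitrile in place of the nitro group on the shared core. Nothing in hand gives a reason for the step from isopropyl to tert-butyl.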